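Fluorine on the benzo ring of a thioamide chromone

The source may hold more compounds than are shown below. What is called first, only, known or untested is meant among the compounds shown, and "the series" means these compounds.

Of the compounds shown here, two sharing one core have been measured in a functional assay on PC-3 cells (Homo sapiens) for inhibition, read by sulforhodamine B assay, with a stated time of 48 h; on this read-out higher numbers stand for weaker inhibition and lower numbers for stronger inhibition. Compound 1 `O=c1c(C(=S)Nc2ccccc2)coc2cc(Cl)ccc12` gives 90800 nM in this assay. Compound 2 `O=c1c(C(=S)Nc2ccccc2)coc2ccccc12` gives 60600 nM in this assay. Among the compounds with values here, the step of a 1.5-fold lower number from compound 1 to compound 2 (0.18 log units; within the scatter) is the only comparison available, and it shows that removing the chloro group on the aromatic ring leaves the read-out essentially unchanged. Compound 2 therefore stands level with compound 1; its number is not separated from that of compound 1 by more than the ordinary scatter.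

Compound 3 `O=c1c(C(=S)Nc2ccccc2)coc2ccc(F)cc12` has not yet been measured. It differs from compound 2 in one place: fluoro in place of hydrogen on an aromatic carbon. Within the data shown here, the one measured step that bears on this change is the halogen swap from compound 1 to compound 2, which stayed within the scatter, so a small halogen added at a different position of the same ring gives no ground to expect a shift in this assay beyond the scatter in either direction. The estimate for compound 3 is therefore a number close to that of compound 2, namely 60000 nM, with a range from 25000 nM to 150000 nM, meaning an expected step of a 1.0-fold lower number from compound 2 to compound 3 (0.00 log units; within the scatter).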

Compound 3, half-maximal inhibitory concentration: > 100000 nM
Compound 3: only a limit was reported (the forecaster's own chance of this, stated with the estimate: 15%); middle value at least 1.6-fold (0.22 log units) from the limit.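

In this assay compound 3 reaches only a limit of the assay and not a number, so the fluoro group on this carbon, meta to a fused ring and para to a fused ring, has no exact value of its own: the limit of > 100000 nM in this assay, at which 1 of the 3 values shown sits. The change from hydrogen to fluoro reads as an at least 1.6-fold higher number from compound 2 to compound 3 (0.21 log units; that floor lies within the scatter); this is only a floor, so the true change could lie within the usual scatter or well beyond it, and the data do not settle which. What this adds to the earlier pair, which compared chloro with hydrogen at a different place on the ring and gave a 1.5-fold lower number from compound 1 to compound 2 (0.18 log units; within the scatter), is that fluoro at this position shows no sign of stronger inhibition than hydrogen.

As far as these compounds go, whether an amine or a methoxy group on this same carbon would give a lower number, and so show that the position can carry a group without losing inhibition, stays open. Also open is how a carboxylic acid or a longer chain would read elsewhere on the shared core, since every change shown so far is a single halogen on one ring.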